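Fluoro for bromo on the phenyl triazole

The source may hold more compounds than are shown below. What is called first, only, known or untested is meant among the compounds shown, and "the series" means these compounds.

Compound 1, `CC(C)n1ncc2c(C(=O)NCc3cn(-c4ccc(I)cc4)nn3)cccc21`: in a functional assay on MCF7 cells (Homo sapiens) for inhibition, read by MTT assay, with a stated time of 72 h (on this read-out higher numbers stand for weaker inhibition and lower numbers for stronger inhibition), compound 1 gives > 40000 nM, a limit.
Compound 2, `CC(C)n1ncc2c(C(=O)NCc3cn(-c4cccc(Br)c4)nn3)cccc21`: in this assay compound 2 gives > 40000 nM, also a limit.

The step that the two limits leave unreadable from compound 1 to compound 2 is the only measured one. Compound 2 stands at the limit of > 40000 nM in this assay, at which 2 of the 2 values shown sit. Compound 3, `CC(C)n1ncc2c(C(=O)NCc3cn(-c4cccc(F)c4)nn3)cccc21`, differs from compound 2 by fluoro in place of bromo on an aromatic carbon. No readable step bears on this change, so compound 3 is expected to sit at the limit as well, a step of a number no higher from compound 2 to compound 3 (the limit leaves the size open) in this assay. Compound 3 is estimated at 40000 nM, between 15000 nM and 100000 nM.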

Compound 3, half-maximal inhibitory concentration: > 40000 nM
Compound 3: no number, only a limit; the forecaster's own chance of this, stated with the estimate: 85%; the middle value lies on the limit itself.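

Among the compounds shown here, compound 1, compound 2 and compound 3 each end at a limit, so no step among them can be read: the limit of > 40000 nM in this assay, at which 3 of the 3 values shown sit.
In this assay the compounds shown leave open how far any of these changes on the phenyl group moves inhibition.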